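The source may report more compounds than this note shows. Statements on the series, on what has been measured and on what is new or still open speak of the compounds shown alone.

Measured compounds:
compound 1 `COc1ccc(OC)c(/C=N/NC(=O)Nc2ccc(Oc3ccnc(-c4nncn4CCN(C)C)c3)c(F)c2)c1`: 2070 nM
compound 2 `COc1ccc(/C=N/NC(=O)Nc2ccc(Oc3ccnc(-c4nncn4CCN(C)C)c3)c(F)c2)c(OC)c1`: 1780 nM
compound 3 `CN(C)CCn1cnnc1-c1cc(Oc2ccc(NC(=O)N/N=C/c3ccc(F)cc3)cc2F)ccn1`: 1370 nM

In a functional assay on HT-29 cells (Homo sapiens) for cytotoxicity, read by MTT assay, with a stated time of 72 h (on this read-out lower numbers stand for stronger inhibition and higher numbers for weaker inhibition), the three share one core and differ only in the aromatic ring attached to a carbon with a double bond to nitrogen. Compound 3 sits at the low end of the three numbers, yet the steps of a 1.5-fold lower number from compound 1 to compound 3 (0.18 log units; within the scatter) and a 1.3-fold lower number from compound 2 to compound 3 (0.11 log units; within the scatter) both stay within the scatter, as does a 1.2-fold lower number from compound 1 to compound 2 (0.07 log units; within the scatter), so none of these ring exchanges has shifted the read-out in a way that can be trusted. Compound 4 `CN(C)CCn1cnnc1-c1cc(Oc2ccc(NC(=O)N/N=C/c3c(O)ccc4ccccc34)cc2F)ccn1` is the next change at that same carbon: 2-hydroxynaphthalen-1-yl in place of 4-fluorophenyl on a carbon with a double bond to nitrogen. The two steps ending at compound 3 are the ones that bear on it, since each swaps the ring at this position, and both were small. Among the compounds with values here, the 2-hydroxynaphthalen-1-yl group is larger than any ring tried so far and carries a hydrogen-bond donor, and no measured step covers such a change. The expected step is therefore a 1.1-fold lower number from compound 3 to compound 4 (0.06 log units; within the scatter), within the scatter. Compound 4 is estimated at 1200 nM in this assay, with a range from 400 nM to 3600 nM.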

Compound 4, half-maximal inhibitory concentration: 670 nM
For compound 4 the middle estimate is 1.8-fold (0.25 log units) above the measured one; the measured number falls inside the stated range.
By their numbers in this assay, from the lowest: compound 4; then compounds 3, 2 and 1 (each within the scatter of the next).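

In this assay the ring on this carbon proves able to move the read-out, which none of the earlier exchanges showed: 2-hydroxynaphthalen-1-yl gives a 2.0-fold lower number from compound 3 to compound 4 (0.31 log units; beyond the scatter) and, against the two dimethoxyphenyl compounds, a 2.7-fold lower number from compound 2 to compound 4 (0.42 log units; beyond the scatter) and a 3.1-fold lower number from compound 1 to compound 4 (0.49 log units; beyond the scatter). All three steps are modest, but they place compound 4 lowest of the four, with every gap beyond the scatter. Nothing available explains this shift.

This single exchange adds a hydroxyl group and enlarges the aromatic system together, so the compounds shown cannot separate the two changes; a plain naphthalen-1-yl group and a 2-hydroxyphenyl group would each isolate one of them. As far as these compounds go, how this position responds to a ring carrying an amine or a carboxylic acid also remains open.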